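Trimming ethoxy to methoxy in a cyano-bearing series

The source may report more compounds than this note shows. Statements on the series, on what has been measured and on what is new or still open speak of the compounds shown alone.

Values in a functional assay on HCT-116 cells (Homo sapiens) for cytotoxicity, read by scintillation counting and thymidine incorporation, with a stated time of 72 h; on this read-out higher numbers stand for weaker inhibition and lower numbers for stronger inhibition:
- compound 1 `CCOc1cc(C(=CC#N)c2cc(OC)cc(OC)c2)ccc1OC`: 34 nM
- compound 2 `CCOc1cc(C(=CC#N)c2cccc(OC)c2)ccc1OC`: 450 nM
- compound 3 `COc1cc(OC)cc(C(=C(C)C)c2ccc(OC)c(O)c2)c1`: 970 nM

Compound 1 gives the lowest number of the three, at 34 nM, while compound 2 gives 450 nM and compound 3 gives 970 nM.

The next compound to be tested is compound 4 `COc1cc(OC)cc(C(=CC#N)c2ccc(OC)c(OC)c2)c1`, which differs from compound 1 in one place: hydrogen in place of methyl on a saturated chain carbon bound to an oxygen on an aromatic ring. Hydrogen stands in place of methyl on a saturated chain carbon bound to an oxygen on an aromatic ring, so ethoxy becomes methoxy.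

Going by the values given here, no measured pair makes this exact change. Among the compounds with values here, the only measured step is a 13-fold higher number from compound 1 to compound 2 (1.12 log units; beyond the scatter), and it comes from a different edit, hydrogen in place of methoxy on an aromatic carbon. That large step shows that one edit can move the number a long way in this small set, but it is only indirect evidence here. The new edit removes a single carbon and keeps the oxygen, whereas compound 2 lost a whole methoxy in a 13-fold higher number from compound 1 to compound 2 (1.12 log units; beyond the scatter), so a much smaller step is expected in this assay, probably within the scatter and with no firm direction.

The estimated step is a 1.3-fold higher number from compound 1 to compound 4 (0.12 log units; within the scatter). For compound 4 the expected value is 45 nM, with an estimated range from 15 nM to 140 nM.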

Compound 4, half-maximal inhibitory concentration: 18 nM
The estimate for compound 4 lay 2.5-fold (0.40 log units) above the measured number; the measured number falls inside the stated range.
By their numbers in this assay, from the lowest: compounds 4 and 1 (each within the scatter of the next); then compound 2; then compound 3.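

In this assay, cutting ethoxy back to methoxy gives a 1.9-fold lower number from compound 1 to compound 4 (0.28 log units; within the scatter), so the two compounds cannot be told apart on this read-out. Going by these compounds alone, the only earlier step, a 13-fold higher number from compound 1 to compound 2 (1.12 log units; beyond the scatter), showed that a single edit elsewhere on the molecule, hydrogen in place of methoxy on an aromatic carbon, can shift the number by a large amount; the new result shows that losing a methyl from a saturated chain carbon bound to an oxygen on an aromatic ring does not have a comparable effect on the core of compound 1. Nothing in the data explains why this edit leaves the number within the scatter.

The compounds shown compare only ethoxy and methoxy at this place, so it remains open whether a longer chain such as propoxy, a branched chain such as isopropoxy, or an amine in place of the oxygen would also leave the number within the scatter. Going by these compounds, it is also open whether the same change from ethoxy to methoxy would behave alike on the core of compound 2, which carries one methoxy fewer.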